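Cyclohexyl in Place of a Phenyl-Capped Chain

A few compounds are considered here, and "the series" means these few. Any claim that something is new, unique, unknown or untested is made for them only; others in the source may bear on it.

Of the compounds shown here, two sharing one core have been measured in an assay on membranes from lung (Cavia porcellus) for binding affinity to cysteinyl leukotriene receptor (Homo sapiens); on this read-out higher numbers stand for weaker inhibition and lower numbers for stronger inhibition. Compound 1 `CCCCC/C=C/C/C=C/COc1ccccc1C(SCCC(=O)O)SCCC(=O)O` gives 1000 nM in this assay. Compound 2 `O=C(O)CCSC(SCCC(=O)O)c1ccccc1OCCCCCCc1ccccc1` gives 11500 nM in this assay, the higher of the two numbers, and its gap to compound 1 lies well beyond the scatter of repeated measurements. No pair among these two differs in only one place, so no single step can be read from them.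

Compound 3 `O=C(O)CCSC(SCCC(=O)O)c1ccccc1OCCCC1CCCCC1` carries the same core as compound 2 and differs from it in one respect: cyclohexyl in place of 3-phenylpropyl on a saturated chain carbon, three bonds along the chain from an oxygen on an aromatic ring. For the measured compounds named here, with only two measured compounds, and neither step a clean one-place change, the direction of this change cannot be read from the data. Compound 3 is expected to give about 20000 nM in this assay, within a range from 5000 nM to 80000 nM. The expected step is a 1.7-fold higher number from compound 2 to compound 3 (0.24 log units; within the scatter), a small weakening that may well stay within the usual scatter.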

Compound 3, inhibition constant: 1010 nM
The estimate for compound 3 lay 20-fold (1.30 log units) above the measured number; measured number outside the range, below it.
By their numbers in this assay, from the lowest: compounds 1 and 3 (each within the scatter of the next); then compound 2.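

In this assay, cyclohexyl in place of 3-phenylpropyl gives an 11-fold lower number from compound 2 to compound 3 (1.06 log units; beyond the scatter), which shows that the group at this saturated chain carbon can strongly change the read-out. The other listed change, 2-cyclohexylethyl in place of deca-1,4-dien-1-yl, gives a 1.0-fold higher number from compound 1 to compound 3 (0.00 log units; within the scatter), so a chain ending in a non-aromatic ring can match the two-double-bond chain of compound 1 within the scatter. No measured evidence available here accounts for either result.

Going by these compounds, the step from compound 2 to compound 3 changes the ring type and the chain length together, so the share of each remains open. A phenyl ring on the shorter chain of compound 3, or a cyclohexyl ring on the longer chain of compound 2, would be needed to separate them.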